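The source may hold more compounds than are shown below. What is called first, only, known or untested is meant among the compounds shown, and "the series" means these compounds.

In a functional assay on HeLa cells (Homo sapiens) for antiproliferative activity, read by MTT assay, with a stated time of 24 h; a lower number here means a stronger inhibitor, a higher number a weaker inhibitor:
Compound 1 `COC(=O)c1scc(-c2ccc(NC(=O)c3cccc(I)c3)cc2)c1OC`: 12700 nM
Compound 2 `COC(=O)c1scc(-c2ccc(NC(=O)c3ccc(OC)nc3)cc2)c1OC`: 24400 nM

Compound 2 has one measured neighbour, and their two values lie within the scatter of each other. Compound 3 `COC(=O)c1scc(-c2ccc(NC(=O)c3ccc(C(F)(F)F)cc3)cc2)c1OC` is unmeasured and carries 4-(trifluoromethyl)phenyl in place of 6-methoxypyridin-3-yl on a carbonyl carbon. For the measured compounds named here, the only measured step at that carbonyl carbon is a 1.9-fold higher number from compound 1 to compound 2 (0.28 log units; within the scatter), so no step beyond the scatter is expected in this assay. The expected step is a 1.4-fold lower number from compound 2 to compound 3 (0.13 log units; within the scatter). For compound 3 the estimate is 18000 nM, with an expected range from 7000 nM to 45000 nM.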

Compound 3, half-maximal inhibitory concentration: 14400 nM
For compound 3 the middle estimate is 1.3-fold (0.10 log units) above the measured one, within the range that was stated.
By their numbers in this assay, from the lowest: compounds 1, 3 and 2 (each within the scatter of the next).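

In this assay, 4-(trifluoromethyl)phenyl on the carbonyl carbon stays within the scatter of both earlier groups (a 1.7-fold lower number from compound 2 to compound 3 (0.23 log units; within the scatter); a 1.1-fold higher number from compound 1 to compound 3 (0.05 log units; within the scatter)). This change replaces 6-methoxypyridin-3-yl, with its ring hetero atom and hydrogen-bond acceptors, by a ring of carbon only carrying none, and the numbers show no separation. No supporting evidence bears on this result.

Still open, as far as these compounds go, is whether an amine or a carboxylic acid on this carbonyl carbon would give a step beyond the scatter. Changes elsewhere on the shared core also remain open.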